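The source may report more compounds than this note shows. Statements on the series, on what has been measured and on what is new or still open speak of the compounds shown alone.

The three measured compounds in a functional assay on MCF7 cells (Homo sapiens) for cytotoxicity, read by MTT assay, with a stated time of 72 h (on this read-out higher numbers stand for weaker inhibition and lower numbers for stronger inhibition), are as follows.
Compound 1 `Cc1cc(=O)n(-c2ccccc2OC(F)(F)F)nc1C(=O)Nc1ccc(Oc2ncnc3ccsc23)cc1` gives 23800 nM.
Compound 2 `Cc1cc(=O)n(-c2cccc(F)c2)nc1C(=O)Nc1ccc(Oc2ncnc3ccsc23)cc1` gives 6410 nM.
Compound 3 `Cc1cc(=O)n(-c2ccccc2OC(F)(F)F)nc1C(=O)Nc1ccc(Oc2ncnc3sccc23)c(F)c1` gives > 40000 nM, which is a limit of the assay and not a number.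

Compound 2 arises from compound 1 by a single change, (3-fluorophenyl in place of 2-(trifluoromethoxy)phenyl on an aromatic nitrogen). The step that this change made, a 3.7-fold lower number from compound 1 to compound 2 (0.57 log units; beyond the scatter), is modest but beyond the scatter. Compound 3 is related to compound 1, but the difference between the two cores is not broken down here. Compound 4 `Cc1cc(=O)n(-c2cccc(F)c2)nc1C(=O)Nc1ccc(Oc2ncnc3sccc23)c(F)c1` has not yet been measured in this assay; it arises from compound 3 by 3-fluorophenyl in place of 2-(trifluoromethoxy)phenyl on an aromatic nitrogen, the same change at the same place as that from compound 1 to compound 2. For compound 3 the value stands at the limit (the limit of > 40000 nM in this assay, at which 1 of the 3 values shown sits). For the measured compounds named here, compound 4 is expected to show a step of about an at least 2.6-fold lower number from compound 3 to compound 4 (0.42 log units; beyond the scatter), set beside a 3.7-fold lower number from compound 1 to compound 2 (0.57 log units; beyond the scatter), because the earlier step of a 3.7-fold lower number from compound 1 to compound 2 (0.57 log units; beyond the scatter) is the only guide to what this change does. Compound 4 is therefore estimated at 15000 nM, within a range from 5000 nM to 40000 nM.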

Compound 4, half-maximal inhibitory concentration: 17300 nM
Compound 4: the middle estimate sits 1.2-fold (0.06 log units) below what was measured; measured number inside the range.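

In this assay compound 3 gives > 40000 nM, which is a limit of the assay and not a number. On the core of compound 3, putting 3-fluorophenyl in place of 2-(trifluoromethoxy)phenyl on the aromatic nitrogen again gives a lower number, an at least 2.3-fold lower number from compound 3 to compound 4 (0.36 log units; beyond the scatter), so in these two pairs the direction of the step carries from one core to the other. This does not show that the size of the step carries over as well: the same change on two cores in this assay, a 3.7-fold lower number (0.57 log units; beyond the scatter) from compound 1 to compound 2 and an at least 2.3-fold lower number (0.36 log units; beyond the scatter) from compound 3 to compound 4; the limit leaves it open whether they differ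

The compounds shown leave open what other groups would do at this aromatic nitrogen, for instance an unsubstituted phenyl, a phenyl bearing a methoxy group or an amine, or a plain alkyl chain in place of the aromatic ring. They also leave open how much of the difference between the two cores comes from each of its parts, since that difference is not broken down into single changes.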